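Swapping a Benzyl Substituent on the Indole Nitrogen

A few compounds are considered here, and "the series" means these few. Any claim that something is new, unique, unknown or untested is made for them only; others in the source may bear on it.

Measured so far:
compound 1 `CCCCCCCn1ccc2cc(/C(C)=C/C(=O)Nc3ccccc3OCCCC(=O)O)ccc21`: 120 nM
compound 2 `C/C(=C\C(=O)Nc1ccccc1OCCCC(=O)O)c1ccc2c(ccn2Cc2ccc(C(F)(F)F)cc2)c1`: 300 nM

Within the data shown here, in an assay on Prostate gland for inhibition of steroid 5-alpha-reductase (Rattus norvegicus) (on this read-out higher numbers stand for weaker inhibition and lower numbers for stronger inhibition), compound 2 gives 300 nM, the higher of the two numbers; the only step recorded, a 2.5-fold higher number from compound 1 to compound 2 (0.40 log units; beyond the scatter), exchanged a hexyl for a 4-(trifluoromethyl)benzyl group and is beyond the scatter. Compound 3 `COc1ccc(Cn2ccc3cc(/C(C)=C/C(=O)Nc4ccccc4OCCCC(=O)O)ccc32)cc1` differs from compound 2 by methoxy in place of trifluoromethyl on an aromatic carbon. Among the measured compounds shown here, no measured step touches that position, so the recorded step offers little guidance. Compound 3 is expected to give about 250 nM, with a range from 100 nM to 700 nM. The expected step is a 1.2-fold lower number from compound 2 to compound 3 (0.08 log units; within the scatter), no more than the scatter.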

Compound 3, half-maximal inhibitory concentration: 480 nM
Beside the measured number, compound 3's estimate is 1.9-fold (0.28 log units) below it; low and high end bracket the measured number.
By their numbers in this assay, from the lowest: compound 1; then compounds 2 and 3 (each within the scatter of the next).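

In this assay, methoxy in place of trifluoromethyl on this aromatic carbon gives a 1.6-fold higher number from compound 2 to compound 3 (0.20 log units; within the scatter), so these two quite different groups cannot be told apart on this read-out. The 4-methoxybenzyl group also shows a 4.0-fold higher number from compound 1 to compound 3 (0.60 log units; beyond the scatter), leaving compound 1, with its hexyl group, the strongest inhibitor of the three. No measurement available here offers an explanation for either step. Still open, from the compounds shown here alone, is how an amine or a carboxylic acid on this aromatic carbon would compare, and whether a longer chain in place of hexyl would give a lower number.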